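Replacing the Amino-Bearing Ring with a Chlorinated One

The source may report more compounds than this note shows. Statements on the series, on what has been measured and on what is new or still open speak of the compounds shown alone.

Compound 2 `COc1cc(-c2ncnn2-c2cccc(N)c2)cc(OC)c1OC` stands at the limit of a functional assay on A549 cells (Homo sapiens) for antiproliferative activity, read by MTT assay, with a stated time of 72 h; a lower number here means a stronger inhibitor, a higher number a weaker inhibitor: in this assay compound 2 gives > 10000 nM, which is a limit and not a number. Compound 1 `COc1ccccc1-c1ncnn1-c1cc(OC)c(OC)c(OC)c1` also reaches only a limit in this assay, giving > 10000 nM. Compound 3 `COc1ccc(-c2ncnn2-c2cc(OC)c(OC)c(OC)c2)cc1` gives 520 nM in this assay. Within the data shown here, the single measured step, an at least 19-fold lower number from compound 1 to compound 3 (1.28 log units; beyond the scatter), sits on the aromatic carbon, not on the aromatic nitrogen where compound 2 changes into compound 4 `COc1cc(-c2ncnn2-c2ccc(Cl)cc2)cc(OC)c1OC`: 4-chlorophenyl in place of 3-aminophenyl on an aromatic nitrogen. As far as these compounds go, that step shows how much the placement of a substituent on one ring can matter, although the limit of > 10000 nM in this assay, at which 2 of the 3 values shown sit, means its true size is unknown. Among the measured compounds shown here, no measured step touches the ring on the aromatic nitrogen, so the expectation for compound 4 rests only on the change itself and on where compound 2 stands. The chemist expects compound 4 to move to a measurable number, with the step of an at least 3.3-fold lower number from compound 2 to compound 4 (0.52 log units; beyond the scatter) expected as a gain. The estimate for compound 4 in this assay is 3000 nM, between 400 nM and 20000 nM.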

Compound 4, half-maximal inhibitory concentration: > 10000 nM
Compound 4 was reported as a limit (the forecaster's own chance of this, stated with the estimate: 40%); middle value at least 3.3-fold (0.52 log units) away from the limit.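

In this assay compound 4 gives > 10000 nM as a limit and not a number. Among these compounds, compound 2 also stands at a limit, so no step from compound 2 to compound 4 can be read: the limit of > 10000 nM in this assay, at which 3 of the 4 values shown sit. The compounds shown leave open how far beyond that limit either compound lies, and so whether 4-chlorophenyl and 3-aminophenyl differ at all on the aromatic nitrogen.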